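The source may hold more compounds than are shown below. What is called first, only, known or untested is meant among the compounds shown, and "the series" means these compounds.

Of the compounds shown here, two with a shared core have been measured so far in a functional assay on HCT-116 cells (Homo sapiens) for cytotoxicity, read by sulforhodamine B assay, with a stated time of 24 h; a lower number here means a stronger inhibitor, a higher number a weaker inhibitor. Compound 1 (`N#CCC(=O)N/N=C1\C(=O)Nc2ccc(S(=O)(=O)N3CCOCC3)cc21`) gives 10300 nM and compound 2 (`O=C1Nc2ccc(S(=O)(=O)N3CCOCC3)cc2/C1=N/NC(=O)c1ccccc1`) gives 28900 nM as the higher of the two numbers, which makes compound 2 the weaker inhibitor of the pair. Within the data shown here, the one measured step (a 2.8-fold higher number from compound 1 to compound 2 (0.45 log units; beyond the scatter)) is modest and puts phenyl in place of cyanomethyl on a carbonyl carbon. Compound 3 (`CC(=O)c1cccc(/N=C2\C(=O)Nc3ccc(S(=O)(=O)N4CCOCC4)cc32)c1`) remains unmeasured. It has 3-acetylphenyl in place of benzamido on a double-bonded nitrogen. Among the measured compounds shown here, no measured step covers that exchange, so the earlier step serves only as a guide to size, and a similarly modest move toward a lower number is expected in this assay for this compound. The expected move is (a 2.4-fold lower number from compound 2 to compound 3 (0.38 log units; beyond the scatter)). Compound 3 is estimated at 12000 nM with 4000 nM to 36000 nM as the expected range.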

Compound 3, half-maximal inhibitory concentration: 29000 nM
Compound 3: middle estimate off by 2.4-fold (0.38 log units), on the low side; the range from low to high includes it.
By their numbers in this assay, from the lowest: compound 1; then compounds 2 and 3 (each within the scatter of the next).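

In this assay, among these compounds, the exchange at this double-bonded nitrogen gives a 1.0-fold higher number from compound 2 to compound 3 (0.00 log units; within the scatter), so 3-acetylphenyl, with 0 hydrogen-bond donors, and benzamido, with 1, cannot be told apart by their numbers, even though compound 3 lacks the hydrazone-type link of the earlier compounds and carries its aromatic ring directly on that nitrogen. The step of a 2.8-fold higher number from compound 1 to compound 3 (0.45 log units; beyond the scatter) shows that ((cyanomethyl)carbonyl)amino also stands apart from this second, differently built group, leaving compound 1 as the strongest inhibitor of the three. Nothing given here explains these results.

From the compounds shown here alone, it remains open whether an amine or a carboxylic acid in place of the acetyl of 3-acetylphenyl would move the number in either direction. Going by these compounds, it is also open whether a longer chain in place of cyanomethyl would keep the lower number of compound 1.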